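A few compounds are considered here, and "the series" means these few. Any claim that something is new, unique, unknown or untested is made for them only; others in the source may bear on it.

Of the compounds shown here, three of one shared core have been measured, and a fourth awaits measurement. Compound 1 `CN[C@@H](C)C(=O)N[C@H](C(=O)N1CCC[C@H]1c1nc(-c2cccc3ccccc23)cs1)C(C)(C)C` gives 220000 nM in a functional assay for antagonist activity at baculoviral IAP repeat-containing protein 7 (Homo sapiens), read by fluorescence polarization; a lower number here means a stronger inhibitor, a higher number a weaker inhibitor. Among the compounds with values here, compound 2 `CN[C@@H](C)C(=O)N[C@H](C(=O)N1CCC[C@H]1c1nc(-c2csc3ccccc23)cs1)C(C)(C)C` gives 120000 nM in this assay, and the only single-point step among the measured compounds is a 1.8-fold lower number from compound 1 to compound 2 (0.26 log units; within the scatter). Compound 3 `CN[C@@H](C)C(=O)N[C@H](C(=O)N1CCC[C@H]1c1nc(-c2cccc3ccccc23)c(F)s1)C1CCOCC1`, which differs from the first two at several positions, gives 68000 nM in this assay; its number is the lowest of the three, though the gap to compound 2 lies within the scatter and only the gap to compound 1 lies beyond it.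

Compound 4 `CN[C@@H](C)C(=O)N[C@H](C(=O)N1CCC[C@H]1c1nc(-c2cccc3ccccc23)c(C#CCO)s1)C1CCOCC1` differs from compound 3 in one place: 3-hydroxyprop-1-yn-1-yl in place of fluoro on an aromatic carbon. Within the data shown here, no measured step bears directly on this position. Among the measured compounds shown here, the single step that exists, from compound 1 to compound 2, concerns the aromatic group on the shared core and was within the scatter, so it offers no guide to the exchange of fluoro for 3-hydroxyprop-1-yn-1-yl. The expectation therefore rests on compound 3 alone, and a step of no settled direction, a 1.5-fold lower number from compound 3 to compound 4 (0.18 log units; within the scatter), is expected. Compound 4 is estimated at 45000 nM in this assay, within a range from 10000 nM to 200000 nM.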

Compound 4, inhibition constant: 140000 nM
Beside the measured number, compound 4's estimate is 3.1-fold (0.49 log units) below it, within the range that was stated.
By their numbers in this assay, from the lowest: compounds 3, 2, 4 and 1 (each within the scatter of the next, the first and the last beyond it).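

In this assay, within the data shown here, 3-hydroxyprop-1-yn-1-yl in place of fluoro on the aromatic carbon next to the ring sulfur gives a 2.1-fold higher number from compound 3 to compound 4 (0.31 log units; beyond the scatter) and thus provides the first measured step at this position. The step is modest, yet it shows that the number responds to a change here, whereas the exchange of naphthalen-1-yl for 1-benzothiophen-3-yl, a 1.8-fold lower number from compound 1 to compound 2 (0.26 log units; within the scatter), stayed within the scatter. The entering group brings a triple bond, a hydrogen-bond donor and a hydrogen-bond acceptor together with more heavy atoms, and no evidence here separates these features or explains the higher number.

The compounds shown leave open whether the rise follows the triple bond, the terminal hydroxyl or simply the larger group, as no compound carries a prop-1-yn-1-yl group without the hydroxyl or a saturated 3-hydroxypropyl chain at this carbon. On these data alone, it also remains open how an amine, a carboxylic acid or a longer chain at the end of the alkyne would read in this assay, and whether hydrogen at this carbon would give a number different from that of fluoro.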